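The compounds below may be only part of what the source reports. "The series", "measured", "known", "first", "only" and "open" are said of these compounds alone.

Among the compounds with values here, compound 2 `O=C1Nc2ccc(Cl)cc2C(CNC(=O)c2ccc(C(F)(F)F)cc2)(C(F)(F)F)O1` gives 813 nM in an assay for inhibition of very long chain fatty acid elongase 6 (Homo sapiens) (a higher number here means a weaker inhibitor, a lower number a stronger inhibitor), and stands highest of the two numbers so far. Its nearest neighbour is compound 1 `Cc1ccc(C(=O)NCC2(C(F)(F)F)OC(=O)Nc3ccc(Cl)cc32)cc1`, which gives 38 nM in this assay; the step of a 21-fold higher number from compound 1 to compound 2 (1.33 log units; beyond the scatter) shows how strongly the group on that aromatic carbon sets the number. Compound 3 `O=C1Nc2ccc(Cl)cc2C(CNC(=O)c2ccc(-c3ccccc3)cc2)(C(F)(F)F)O1` carries the change (phenyl in place of trifluoromethyl on an aromatic carbon), para to a large group. Within the data shown here, no measured step covers a phenyl at this position, so the step of a 21-fold higher number from compound 1 to compound 2 (1.33 log units; beyond the scatter) is the only one that bears on it, and it says only that a change here can be large in either direction. Given that, the expectation for compound 3 in this assay is a moderate step downward, a 2.7-fold lower number from compound 2 to compound 3 (0.43 log units; beyond the scatter), with wide uncertainty. Compound 3 is therefore estimated at 300 nM, in the range 60 nM to 1500 nM.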

Compound 3, half-maximal inhibitory concentration: > 10000 nM
Compound 3 gave a limit, no number; the forecaster's own chance of this, stated with the estimate: 5%; at least 33-fold (1.52 log units) between middle value and limit.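

Compound 3 reads > 10000 nM in this assay, which is a limit of the assay and not a number. Phenyl on this aromatic carbon, para to a large group, moves the number the same way as trifluoromethyl and further, with an at least 12-fold higher number from compound 2 to compound 3 (1.08 log units; beyond the scatter) and an at least 260-fold higher number from compound 1 to compound 3 (2.42 log units; beyond the scatter), so among the three groups shown, methyl gives the lowest number and neither replacement lowers it. From the compounds shown here alone, how far the number of compound 3 lies past the limit stays unknown, so both steps are lower bounds on the true size: the limit of > 10000 nM in this assay, at which 1 of the 3 values shown sits.

The compounds shown leave open whether a methoxy group or an amine on this carbon would give a number below that of compound 1 at 38 nM. They also leave open whether the same order of groups holds with another group in place of the chlorine on the shared core.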